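The source may hold more compounds than are shown below. What is called first, only, known or untested is meant among the compounds shown, and "the series" means these compounds.

Measured so far in an ADME assay on microsomes from liver (Mus musculus) for metabolic stability, read by LC-MS, with a stated time of 30 min, tested at 1 ug/mL; a higher number here means that more of the compound is left, a lower number that less of the compound is left:

compound 1 `CC(C)C(=O)N1CCC(C[C@@H](c2nc3ccc(F)cc3n2C2CC2)N2C(=O)CN(c3ccc(Oc4ccc(F)cc4)cc3)C2=O)CC1` gives 54%
compound 2 `Cc1ccc2nc([C@H](CC3CCN(C(=O)C(C)C)CC3)N3C(=O)CN(c4ccc(Oc5ccc(F)cc5)cc4)C3=O)n(C3CC3)c2c1` gives 43%
compound 3 `COc1ccc(Oc2ccc(N3CC(=O)N([C@@H](CC4CCN(C(=O)C(C)C)CC4)c4nc5ccc(C)cc5n4C4CC4)C3=O)cc2)cc1` gives 22.8%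

Compound 2 stands second of the three: compound 1 lies higher, by a number 11 percentage points lower from compound 1 to compound 2 (beyond the scatter), and compound 3 lies lower, by a number 20.2 percentage points lower from compound 2 to compound 3 (beyond the scatter). Both of these steps are exchanges on an aromatic carbon of the outer ring, and both lower the fraction remaining in this assay.

Compound 4 `Cc1ccc2nc([C@H](CC3CCN(C(=O)C(C)C)CC3)N3C(=O)CN(c4ccc(Oc5ccc(F)cc5)cc4)C3=O)n(C)c2c1` is the next point. It differs from compound 2 in one place: methyl in place of cyclopropyl on an aromatic nitrogen. Among the compounds with values here, neither measured step touches the aromatic nitrogen of the five-membered ring, so there is no step of this kind to draw on; the two known steps only show that single changes at the edges of this core shift the reading by modest amounts. For the exchange of cyclopropyl for methyl no direction can be read from the data, and the expected step is small, a number 3 percentage points lower from compound 2 to compound 4 (within the scatter), within or near the scatter. Compound 4 is therefore expected at 40%, in the range 24% to 58%.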

Compound 4, percent of the compound remaining: 10.6%
Compound 4: the middle estimate sits 29.4 percentage points above what was measured; the whole stated range lies above it.
By their numbers in this assay, from the lowest: compound 4; then compound 3; then compound 2; then compound 1.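

In this assay, the group on the aromatic nitrogen of the five-membered ring proves a sensitive point in the series: methyl in place of cyclopropyl gives a number 32.4 percentage points lower from compound 2 to compound 4 (beyond the scatter), a large step, whereas the two exchanges on aromatic carbon were modest. This position therefore carries more weight for the fraction remaining than the earlier compounds could indicate, and among the groups shown here, cyclopropyl goes with more compound left than methyl. No measurement at hand accounts for this step.

With only two groups shown on this nitrogen, it remains open whether an ethyl or isopropyl group would read closer to cyclopropyl or to methyl. Going by these compounds, it is also open whether the step keeps its size alongside the other substituents of compound 1 or compound 3.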